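Swapping methyl for fluoro in compound 3

The source may report more compounds than this note shows. Statements on the series, on what has been measured and on what is new or still open speak of the compounds shown alone.

Compound 1 `Cc1cccc(-n2cc(-c3ccc(/C=C4\C(=O)Nc5ccccc54)cc3)nn2)c1`: 4690 nM
Compound 2 `O=C1Nc2ccccc2/C1=C/c1ccc(-c2cn(-c3ccc(F)cc3)nn2)cc1`: 16700 nM
Compound 3 `Cc1cccc(-n2cc(-c3ccc(/C=C4\C(=O)Nc5ccc(F)cc54)cc3)nn2)c1`: 6810 nM

All three were measured in a functional assay on MKN-45 cells (Homo sapiens) for inhibition, read by CCK-8 assay, with a stated time of 24 h; on this read-out lower numbers stand for stronger inhibition and higher numbers for weaker inhibition. Compound 3 lies within the scatter of compound 1 and well under compound 2. Compound 4 `O=C1Nc2ccc(F)cc2/C1=C/c1ccc(-c2cn(-c3cccc(F)c3)nn2)cc1` has fluoro in place of methyl on an aromatic carbon, 3-methylphenyl to 3-fluorophenyl: fluoro in place of methyl on an aromatic carbon. Going by the values given here, the closest precedent is the modest 3.6-fold higher number from compound 1 to compound 2 (0.55 log units; beyond the scatter), where 4-fluorophenyl replaced 3-methylphenyl on an aromatic nitrogen. The fluoro of compound 3 on the core gave a 1.5-fold higher number from compound 1 to compound 3 (0.16 log units; within the scatter), within the scatter, so the earlier swap may carry over to this background. A similar or smaller rise is therefore expected in this assay, an estimated 1.8-fold higher number from compound 3 to compound 4 (0.25 log units; within the scatter). The estimate for compound 4 is 12000 nM, with an expected range of 5500 nM to 26000 nM.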

Compound 4, half-maximal inhibitory concentration: 8190 nM
Estimate against measurement, compound 4: 1.5-fold (0.17 log units) above; measured number inside the range.
By their numbers in this assay, from the lowest: compounds 1, 3 and 4 (each within the scatter of the next); then compound 2.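

On the fluorinated core, fluoro in place of methyl on this aromatic carbon gives a 1.2-fold higher number from compound 3 to compound 4 (0.08 log units; within the scatter), so in this assay the position, meta to a large group, shows no distinguishable preference between the two groups. This 3-fluorophenyl result does not repeat the rise beyond the scatter seen with 4-fluorophenyl, a 3.6-fold higher number from compound 1 to compound 2 (0.55 log units; beyond the scatter), although those two steps also differ in their core. Nothing given here explains the result. The compounds shown leave open whether a larger or charged group at this position, such as an amine, a carboxylic acid or a longer chain, would move the value beyond the scatter.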